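The source may hold more compounds than are shown below. What is called first, only, known or untested is meant among the compounds shown, and "the series" means these compounds.

Measured so far in a functional assay on MCF7 cells (Homo sapiens) for inhibition, read by MTT assay, with a stated time of 72 h; on this read-out lower numbers stand for stronger inhibition and higher numbers for weaker inhibition:

Compound 1 `N#Cc1c(Nc2cccc(Cl)c2)nc(SCc2cn(Cc3ccccc3Cl)nn2)nc1-c1ccccc1` gives 12000 nM in this assay.
Compound 2 `Cc1cccc(Nc2nc(SCc3cn(Cc4ccccc4Cl)nn3)nc(-c3ccccc3)c2C#N)c1` gives 19600 nM in this assay.
Compound 3 `Cc1ccccc1Nc1nc(SCc2cn(Cc3ccc(Cl)cc3)nn2)nc(-c2ccccc2)c1C#N` reaches only a limit of this assay, namely > 64000 nM.

For the measured compounds named here, the one completed step within the set, (methyl in place of chloro on an aromatic carbon), runs a 1.6-fold higher number from compound 1 to compound 2 (0.21 log units; within the scatter). The same kind of change, methyl in place of chloro on an aromatic carbon, connects compound 3 to the not yet measured compound 4 `Cc1ccc(Cn2cc(CSc3nc(Nc4ccccc4C)c(C#N)c(-c4ccccc4)n3)nn2)cc1`: here it reads (methyl in place of chloro on an aromatic carbon). The two settings are not identical. In the measured pair the exchange sits meta to a large group and, cut one bond further out, reads 3-chlorophenyl to 3-methylphenyl, (3-chlorophenyl)amino to (3-methylphenyl)amino; in the new pair it sits para to a large group and reads 4-chlorophenyl to 4-methylphenyl, 4-chlorobenzyl to 4-methylbenzyl. How the core of compound 1 differs from the core of compound 3 is not broken down here.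

For compound 4 the expectation is a step of a number no higher from compound 3 to compound 4 (the limit leaves the size open) in this assay, resting on the small measured step of a 1.6-fold higher number from compound 1 to compound 2 (0.21 log units; within the scatter) and on the fact that compound 3 itself stands at the limit given by the limit of > 64000 nM in this assay, at which 1 of the 3 values shown sits. Since only a limit is known for compound 3, the value for compound 4 is estimated near that limit, with a fair chance that only a limit is again returned. The estimate for compound 4 is 64000 nM, expected to fall between 20000 nM and 200000 nM.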

Compound 4, half-maximal inhibitory concentration: > 64000 nM
Compound 4: a limit, no number; the forecaster's own chance of this, stated with the estimate: 65%; the middle value sits exactly at the limit.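

Compound 3 and compound 4 both stand at a limit in this assay, so the exchange of chloro for methyl between them gives no readable step: the limit of > 64000 nM in this assay, at which 2 of the 4 values shown sit.

The compounds shown leave open whether the change from 4-chlorobenzyl to 4-methylbenzyl has any effect on inhibition in this assay, and whether the same exchange behaves alike in the two settings.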